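The compounds below may be only part of what the source reports. "The series", "measured", "known", "first", "only" and "open" are said of these compounds alone.

Compound 2 `CCC[n+]1ccc(CCC(=O)c2cc3cc(OC)c(OC)cc3s2)cc1` is measured in a physicochemical assay for solubility (on this read-out lower numbers stand for lower solubility and higher numbers for higher solubility), where compound 2 gives 16000 ug/mL. Among the compounds with values here, compound 1 `COc1cc2cc(C(=O)CCCCC3CC[N+](C)(Cc4ccccc4)CC3)sc2cc1OC` gives 1000 ug/mL in this assay, so compound 2 stands highest of the two numbers known here, and its gap to compound 1 lies beyond the scatter.

Compound 3 `COc1cc2cc(C(=O)CCc3cc[n+](Cc4ccccc4)cc3)sc2cc1OC` is not yet measured. It differs from compound 2 in one place: phenyl in place of ethyl on a saturated chain carbon bound to an aromatic nitrogen. Within the data shown here, no pair of measured compounds isolates this change, so its size must be guessed. A step downward in this assay is expected, in which compound 3 is estimated to land at 4000 ug/mL, with a range from 1000 ug/mL to 12000 ug/mL. That expectation leans on compound 1, which also carries a benzyl group on a charged nitrogen and gives 1000 ug/mL, and means an estimated step of a 4.0-fold lower number from compound 2 to compound 3 (0.60 log units; beyond the scatter).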

Compound 3, solubility: 2000 ug/mL
Compound 3: the middle estimate sits 2.0-fold (0.30 log units) above what was measured; measured number inside the range.
By their numbers in this assay, from the lowest: compounds 1 and 3 (each within the scatter of the next); then compound 2.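

In this assay, within the data shown here, phenyl in place of ethyl on a saturated chain carbon bound to an aromatic nitrogen gives an 8.0-fold lower number from compound 2 to compound 3 (0.90 log units; beyond the scatter) and so puts a first size on this change, which no earlier pair of compounds isolated. The step lies beyond the scatter, so the group at this position matters for this read-out, and here the entering group with a ring and more carbon goes with the lower number. Nothing shown here accounts for the size of this step.

This is a single pair on one core, so it cannot separate the effect of the aromatic ring from that of the added carbon. A longer chain such as hexyl, or a benzyl group carrying an amine, at this position would help tell these apart.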